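A few compounds are considered here, and "the series" means these few. Any claim that something is new, unique, unknown or untested is made for them only; others in the source may bear on it.

Compound 1, `Cc1cc(N2CC[C@@H](C)[C@@H](N(C)c3ncnc4[nH]ccc34)C2)n2nc(SCc3cc(Cl)ccc3Cl)nc2n1`: 19200 nM
Compound 2, `Cc1cc(N2CC[C@@H](C)[C@@H](N(C)c3ncnc4[nH]ccc34)C2)n2nc(SCc3ccccc3Br)nc2n1`: 21300 nM
Compound 3, `Cc1cc(N2CC[C@@H](C)[C@@H](N(C)c3ncnc4[nH]ccc34)C2)n2nc(SCc3ccc(Cl)cc3)nc2n1`: 18400 nM

These three compounds share one core and differ only in the aryl group carried on a saturated chain carbon bound to a sulfur. In a functional assay on HGC-27 cells (Homo sapiens) for inhibition, read by MTT assay, with a stated time of 72 h (a lower number here means a stronger inhibitor, a higher number a weaker inhibitor), their numbers lie close together: a 1.1-fold higher number from compound 1 to compound 2 (0.05 log units; within the scatter), a 1.0-fold lower number from compound 1 to compound 3 (0.02 log units; within the scatter) and a 1.2-fold lower number from compound 2 to compound 3 (0.06 log units; within the scatter). Compound 3 therefore sits within the scatter of both compound 1 and compound 2, and nothing among the three separates one from another.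

Compound 4, `Cc1cc(N2CC[C@@H](C)[C@@H](N(C)c3ncnc4[nH]ccc34)C2)n2nc(SCc3ccc([N+](=O)[O-])cc3)nc2n1`, follows from compound 3 by a single change at the same aryl group: nitro in place of chloro on an aromatic carbon. The steps measured so far exchanged one halogen pattern for another on that ring, and each of them stayed within the scatter. For the measured compounds named here, none of them brought in a nitro, so there is no measured step that tests this change directly. What the three steps do show is that rearranging substituents on this ring left this assay unmoved, and on that ground the step from compound 3 to compound 4 is expected to be no larger than the scatter, with no direction favoured: a 1.0-fold higher number from compound 3 to compound 4 (0.01 log units; within the scatter).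

Compound 4 is thus estimated at 19000 nM in this assay, with a range from 8000 nM to 45000 nM.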

Compound 4, half-maximal inhibitory concentration: 29400 nM
Compound 4: the middle estimate sits 1.5-fold (0.19 log units) below what was measured, and the stated range covers the measured number.
By their numbers in this assay, from the lowest: compounds 3, 1, 2 and 4 (each within the scatter of the next).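

Nitro is the only substituent among these four compounds that is not a halogen, and it brings three heavy atoms in place of one and two hydrogen-bond acceptors in place of none, yet in this assay the exchange for chloro stays inside the scatter (a 1.6-fold higher number from compound 3 to compound 4 (0.20 log units; within the scatter)). The 4-nitrophenyl group is equally unseparated from the two ortho-free and halogen-rich comparisons: the steps from the other aryl groups read (a 1.4-fold higher number from compound 2 to compound 4 (0.14 log units; within the scatter)) and (a 1.5-fold higher number from compound 1 to compound 4 (0.19 log units; within the scatter)), so the flat picture at this aryl group now extends past halogen patterns to a substituent of a different kind. Nothing measured here accounts for this flat picture.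

The compounds shown all keep a substituted phenyl on a single saturated chain carbon bound to the sulfur, so it remains open whether an amine or a carboxylic acid on that ring, or a longer chain in place of that carbon, would separate from these numbers. The shared core is also the same throughout, so what its other parts contribute in this assay cannot be read from these four compounds.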